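This account rests on a few compounds, and the source may have more. Where it says the series, first, only, none or still open, it means among the compounds named here.

Working notes on the series. Compound 1 `C=C(C)C(=O)N(Cc1ccc(OC)c(O)c1)c1cc(OC)c(OC)c(OC)c1` stands lowest of the two numbers recorded in a functional assay on HCT-116 cells (Homo sapiens) for inhibition, read by MTT assay, with a stated time of 48 h; on this read-out lower numbers stand for stronger inhibition and higher numbers for weaker inhibition: compound 1 gives 200 nM. Among the measured compounds shown here, the only other measured member, compound 2 `COc1ccc(N(Cc2cc(OC)c(OC)c(OC)c2)C(=O)CCl)cc1O`, has the amide nitrogen carrying the benzyl and aryl groups in exchanged places and a chloroacetyl group on the carbonyl; in this assay compound 2 gives 22500 nM, a gap well beyond the scatter, though no single-place comparison between the two is available.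

Compound 3 `COc1ccc(CN(C(=O)CCCCCl)c2cc(OC)c(OC)c(OC)c2)cc1O` keeps the nitrogen substitution of compound 1 and changes only the acyl group: 4-chlorobutyl in place of 1-methylethenyl on a carbonyl carbon. For the measured compounds named here, no measured pair shows this change directly. Given that compound 1 holds 200 nM and that the only compound with a chloroalkyl acyl group, compound 2, sits at 22500 nM, the step is expected to be upward and beyond the scatter, a 25-fold higher number from compound 1 to compound 3 (1.40 log units; beyond the scatter). For compound 3 the estimate in this assay is 5000 nM, with a range from 1000 nM to 30000 nM.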

Compound 3, half-maximal inhibitory concentration: 220 nM
Estimate against measurement, compound 3: 23-fold (1.36 log units) above, outside the stated range (below it).
By their numbers in this assay, from the lowest: compounds 1 and 3 (each within the scatter of the next); then compound 2.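

In this assay, the acyl position on the amide of compound 1 accepts a large change of group: 4-chlorobutyl in place of 1-methylethenyl on a carbonyl carbon gives a 1.1-fold higher number from compound 1 to compound 3 (0.04 log units; within the scatter) and leaves the number within the scatter. For this pair, the double bond of the 1-methylethenyl group is therefore not needed to keep the number at this level, and a saturated chain ending in chlorine serves equally well at this place. Nothing at hand accounts for this match between the two groups.

Going by these compounds, the role of the chlorine remains open, as a plain butyl chain would be needed to separate it from the chain itself. Also open, on these data alone, is whether a longer chloroalkyl chain, an amine or a carboxylic acid at the end of the chain would hold the number.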